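The source may hold more compounds than are shown below. What is called first, only, known or untested is meant among the compounds shown, and "the series" means these compounds.

Measured in a functional assay on HFF cells (Homo sapiens) for cytotoxicity; on this read-out lower numbers stand for stronger inhibition and higher numbers for weaker inhibition:
- compound 1 `CC(=O)OC1C(CBr)OC(n2c(Cl)nc3cc(Cl)c(Cl)cc32)C1OC(C)=O`: 32000 nM
- compound 2 `CC(=O)OC1C(CI)OC(n2c(Cl)nc3cc(Cl)c(Cl)cc32)C1OC(C)=O`: 32000 nM
- compound 3 `COC[C@H]1OC(n2c(Cl)nc3cc(Cl)c(Cl)cc32)[C@H](O)[C@@H]1O`: 32000 nM

Compound 3 stands level with compound 1 and compound 2 at the digits recorded, so the three values give no order within the set. The next compound is compound 4 `O[C@@H]1[C@@H](CBr)OC(n2c(Cl)nc3cc(Cl)c(Cl)cc32)[C@@H]1O`, still to be measured. The change is bromo in place of methoxy on a saturated chain carbon bound to a saturated ring carbon.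

For the measured compounds named here, no measured step covers this exchange directly. Going by the values given here, the only one available is no change at the digits printed from compound 1 to compound 2 (within the scatter), which replaces bromo with iodo at the same place. Compound 1 carries the bromo that enters compound 4, although the two also differ elsewhere, and compound 1 gives 32000 nM. With no movement seen so far, no shift beyond the scatter is expected in this assay, and no direction can be favoured. The expected step is no change at the digits printed from compound 3 to compound 4 (within the scatter). For compound 4 the estimated value is 32000 nM, with an expected range of 12000 nM to 100000 nM.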

Compound 4, half-maximal inhibitory concentration: 32000 nM
Compound 4: middle estimate and measured number agree at the digits printed; the range from low to high includes it.
By their numbers in this assay, from the lowest: compounds 1, 2, 3 and 4 (each within the scatter of the next).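

In this assay the exchange of methoxy for bromo on a saturated chain carbon bound to a saturated ring carbon gives no change at the digits printed from compound 3 to compound 4 (within the scatter) and so extends the flat picture at this place beyond the halogen swap, which gave no change at the digits printed from compound 1 to compound 2 (within the scatter) in the acetylated pair. Here the difference is methoxymethyl to bromomethyl, a change in the kind of group rather than only in the halogen, and compound 4 still reads 32000 nM in this assay with no movement beyond the scatter. Nothing measured on these compounds offers an account of this flat outcome.

Whether any group at this place can move the read-out remains open, since an amine, a carboxylic acid or a longer chain on this carbon does not appear among the compounds shown. For the compounds shown here, no single-place step isolates the acetyl esters either.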